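Swapping the aryl group on the ring nitrogen

The compounds below may be only part of what the source reports. "The series", "measured", "known", "first", "only" and "open" are said of these compounds alone.

Compound 1 `Nc1scc(CN2CCN(c3ccncc3)CC2)c1C(=O)c1ccc(Cl)cc1` and compound 2 `Nc1scc(CN2CCN(c3c(F)cc(F)cc3F)CC2)c1C(=O)c1ccc(Cl)cc1` share one core and differ only in the aryl group on an amine nitrogen in a ring. For the measured compounds named here, in a functional assay on CHO cells with adenosine receptor A1 (Homo sapiens) as the target, read by cAMP accumulation and immunoassay, with a stated time of 6 min, tested at 1 uM (a lower number here means a stronger effect, a higher number a weaker effect of the compound at the concentration tested), compound 1 gives -8.3%, whereas compound 2 gives -56%, the lowest of the two numbers measured so far. Going by the values given here, the only measured step, a number 47.7 percentage points lower from compound 1 to compound 2 (beyond the scatter), lies beyond the scatter and is large. Compound 3 `Nc1scc(CN2CCN(c3ccccc3Cl)CC2)c1C(=O)c1ccc(Cl)cc1` has not yet been measured. It differs from compound 2 in one place: 2-chlorophenyl in place of 2,4,6-trifluorophenyl on an amine nitrogen in a ring. Among the compounds with values here, the single step that bears on this change is the one already mentioned, which exchanged a pyridin-4-yl for a substituted phenyl and lowered the number strongly. Compound 3 keeps a substituted phenyl rather than returning to pyridin-4-yl, so a number near that of compound 2 is expected, perhaps slightly higher. Compound 3 is therefore expected to give -45% in this assay, within a range from -70% to -15%. This estimate means a step of a number 11 percentage points higher from compound 2 to compound 3 (beyond the scatter), expected to stay within the scatter.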

Compound 3, a percentage reported as activity, at one concentration (the size of the read-out at that concentration, not a potency): -5.2%
Compound 3: the middle estimate sits 39.8 percentage points below what was measured, outside the stated range (above it).
By their numbers in this assay, from the lowest: compound 2; then compounds 1 and 3 (each within the scatter of the next).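

In this assay the step of a number 50.8 percentage points higher from compound 2 to compound 3 (beyond the scatter) is large and beyond the scatter, so at this amine nitrogen in a ring, a substituted phenyl as such does not bring the low number seen for compound 2. The step of a number 3.1 percentage points higher from compound 1 to compound 3 (within the scatter) lies within the scatter, so the 2-chlorophenyl and pyridin-4-yl groups cannot be told apart in this read-out, and among these three compounds only compound 2, with its 2,4,6-trifluorophenyl group, stands apart. The exchange of that group for 2-chlorophenyl thus has a large effect on the number, yet nothing available here accounts for the size of that step.

The compounds shown leave open whether the low number of compound 2 needs all three fluorine atoms or would persist with fewer, as a 2-fluorophenyl or 2,4-difluorophenyl group would show. They also leave open whether the chlorine matters in compound 3, since a plain phenyl, or a phenyl bearing a methoxy group, could fall close to compound 2 or close to compound 3.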